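Extending the ether chain of compound 3 to octyl

This account rests on a few compounds, and the source may have more. Where it says the series, first, only, none or still open, it means among the compounds named here.

Compound 1 `CCc1nncn1-c1ccc(OCc2cccc(F)c2)cc1` gives 22.8 mg/kg in a functional assay on the whole organism (strain C57B/6) with Mus musculus as the target, in the maximal electroshock model (a higher number here means that more compound is needed for the effect, a lower number that less compound is needed), and compound 2 `CCc1nncn1-c1ccc(OCc2ccc(C)cc2)cc1` gives 25.5 mg/kg; the step of a 1.1-fold higher number from compound 1 to compound 2 (0.05 log units; within the scatter) stays within the scatter. Compound 3 `CCCOc1ccc(-n2cnnc2CC)cc1` reaches only a limit of this assay, > 100 mg/kg, so it has no firm number and stands at the upper end of the values shown (the limit of > 100 mg/kg in this assay, at which 1 of the 3 values shown sits). The steps of an at least 4.3-fold higher number from compound 1 to compound 3 (0.64 log units; beyond the scatter) and an at least 3.9-fold higher number from compound 2 to compound 3 (0.59 log units; beyond the scatter) are both beyond the scatter: exchanging 3-fluorophenyl or 4-methylphenyl for ethyl on the ether carbon raises the dose needed.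

Compound 4 `CCCCCCCCOc1ccc(-n2cnnc2CC)cc1` differs from compound 3 by pentyl in place of hydrogen on a saturated chain carbon, three bonds along the chain from an oxygen on an aromatic ring. Among the compounds with values here, none of the measured steps lengthens the alkyl chain on the ether; the two steps that touch this position only compare an aromatic group with ethyl, and they give no direction for a longer chain. With compound 3 already at a limit, the expected step is a number no higher from compound 3 to compound 4 (the limit leaves the size open), most likely again ending in a limit. For compound 4 the estimate in this assay is 100 mg/kg, with a range from 40 mg/kg to 300 mg/kg.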

Compound 4, dose for half-maximal effect: 8.8 mg/kg
Compound 4: the middle estimate sits 11-fold (1.06 log units) above what was measured; measured number outside the range, below it.
By their numbers in this assay, from the lowest: compound 4; then compounds 1 and 2 (each within the scatter of the next). At a limit, above all of these: compound 3.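

Compound 3 stays at a limit in this assay and has no firm number: the limit of > 100 mg/kg in this assay, at which 1 of the 4 values shown sits. Lengthening the chain at this position therefore does more than the earlier steps suggested, with pentyl in place of hydrogen giving an at least 11-fold lower number from compound 3 to compound 4 (1.05 log units; beyond the scatter), so the size of this large step remains open on the side of compound 3. An aromatic group on the ether carbon is also not required for a low dose, since heptyl in its place gives a 2.9-fold lower number from compound 2 to compound 4 (0.46 log units; beyond the scatter) and a 2.6-fold lower number from compound 1 to compound 4 (0.41 log units; beyond the scatter).

As far as these compounds go, with only ethyl and heptyl on that carbon, the course of the dose across the chain lengths between them stays open. From the compounds shown here alone, it is also open whether a longer chain, or a chain ending in an amine or a carboxylic acid, would hold the low number of compound 4.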